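Swapping a Bicyclic Ring for a Cyanofluorophenyl Group

The compounds below may be only part of what the source reports. "The series", "measured", "known", "first", "only" and "open" are said of these compounds alone.

Compound 2 `CCOC(=O)C1=C(Nc2ccccc2)S/C(=C\c2cc3ncccc3[nH]2)C1=O` carries the shared core of this small series. In a functional assay on JAR cells (Homo sapiens) for inhibition, tested at 10 uM (on this read-out higher numbers stand for more inhibition at the one concentration tested (going by the name of the read-out) and lower numbers for less inhibition), compound 2 gives 74.8%. Compound 1 `CCOC(=O)C1=C(Nc2ccccc2)S/C(=C\C2CCCCC2)C1=O` differs from it only at the double-bonded chain carbon, and in this assay compound 1 gives 95.2%. Going by the values given here, compound 2 therefore stands lowest of the two numbers known so far, with compound 1 its only neighbour, a number 20.4 percentage points lower from compound 1 to compound 2 (beyond the scatter).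

Compound 3 `CCOC(=O)C1=C(Nc2ccccc2)S/C(=C\c2ccc(F)c(C#N)c2)C1=O` has not yet been measured. Its change from compound 2 is a group of 9 heavy atoms (7 carbon, 1 nitrogen, 1 fluorine; one six-membered aromatic ring of carbon only) in place of a group of 9 heavy atoms (7 carbon, 2 nitrogen; one five-membered aromatic ring with 1 hetero atom, one six-membered aromatic ring with 1 hetero atom), on a double-bonded chain carbon bound to a double-bonded ring carbon. Among the compounds with values here, the one measured step, a number 20.4 percentage points lower from compound 1 to compound 2 (beyond the scatter), bears on this: it shows that the group on that chain carbon can move the number by a modest amount, yet it compares a saturated ring with the bicyclic aromatic group, not that group with a phenyl ring bearing a nitrile and a fluorine. Within the data shown here, no measured step covers an aromatic-for-aromatic exchange, so the direction is uncertain. For compound 3 the expected step is a number 5.2 percentage points higher from compound 2 to compound 3 (within the scatter), a small shift within the scatter. Compound 3 is estimated at 80%, with a range from 60% to 95%.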

Compound 3, a percentage reported as inhibition, at one concentration (the size of the read-out at that concentration, not a potency): 9.9%
Estimate against measurement, compound 3: 70.1 percentage points above; the measured number lies below the stated range.
By their numbers in this assay, from the lowest: compound 3; then compound 2; then compound 1.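

The size of the group does not settle the outcome at this position. The bicyclic group and 3-cyano-4-fluorophenyl have the same heavy-atom count and both are aromatic, yet exchanging one for the other in this assay gives a number 64.9 percentage points lower from compound 2 to compound 3 (beyond the scatter), and the hydrogen-bond donor counted on the leaving group is absent from the entering one. Measured against cyclohexyl, the same substituted phenyl gives a number 85.3 percentage points lower from compound 1 to compound 3 (beyond the scatter), so this one place on the double-bonded chain carbon can take the read-out from strong inhibition to very little, and having an aromatic ring there does not by itself preserve inhibition, as compound 2 and compound 3 show. No measurement on hand explains why the number falls so far.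

The compounds shown leave open whether the drop belongs to the nitrile, to the fluorine or to the pair, a question that plain phenyl, 4-fluorophenyl and 3-cyanophenyl at this place would help to separate. They also leave open whether an amine or a carboxylic acid on that phenyl ring would bring inhibition back.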